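This account rests on a few compounds, and the source may have more. Where it says the series, first, only, none or still open, it means among the compounds named here.

Compound 1 `CC(=O)N1CCC(c2cc3c(-c4ccc(=O)n(C(C)C)c4)ccnc3[nH]2)CC1`: in an ADME assay on microsomes from liver (Homo sapiens) for metabolic stability (a lower number here means slower removal, a higher number faster removal of the compound), compound 1 gives < 3 uL/min, which is a limit of this assay rather than a number.
Compound 2 `CN(C)C(=O)CN1CCC(c2cc3c(-c4ccc(=O)n(C5CCOCC5)c4)ccnc3[nH]2)CC1`: in this assay compound 2 gives 8.2 uL/min.
Compound 3 `Cc1nc2ccc(-c3ccnc4[nH]c(C5CCN(CC(=O)N(C)C)CC5)cc34)cc2n1C(C)C`: in this assay compound 3 gives 63 uL/min.

Of the two numbers shown, compound 2 stands lowest; compound 3 is the nearest and sits higher by a gap beyond the usual scatter. Compound 4 `CN(C)C(=O)CN1CCC(c2cc3c(-c4ccc(=O)n(CC5CCOCC5)c4)ccnc3[nH]2)CC1` differs from compound 2 in one place: (oxan-4-yl)methyl in place of oxan-4-yl on an aromatic nitrogen. Among the measured compounds shown here, no measured pair with such a change is available, so the step in this assay is expected to be small, leaning upward but not clearly beyond the scatter. Compound 4 is therefore estimated at 12 uL/min, within a range from 5 uL/min to 30 uL/min. This expectation corresponds to a step of a 1.5-fold higher number from compound 2 to compound 4 (0.17 log units; within the scatter).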

Compound 4, intrinsic clearance in a liver preparation (reported as CLH), per the amount of preparation that the assay uses: 20 uL/min
The estimate for compound 4 lay 1.7-fold (0.22 log units) below the measured number, and the stated range covers the measured number.
By their numbers in this assay, from the lowest: compound 2; then compound 4; then compound 3. At a limit, below all of these: compound 1.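

With (oxan-4-yl)methyl in place of oxan-4-yl on the aromatic nitrogen, this assay shows a 2.4-fold higher number from compound 2 to compound 4 (0.39 log units; beyond the scatter), so even this small change at this position moves the clearance number beyond the scatter. Among the compounds shown here, the earlier compounds offered no pair differing in one place, so this is the first direct reading of this position. Compound 1 alone sits at a limit, so this step compares two true numbers: the limit of < 3 uL/min in this assay, at which 1 of the 4 values shown sits.

One pair cannot show whether the trend continues. A longer chain such as (oxan-4-yl)ethyl, or a piperidin-4-yl ring carrying an amine, could behave differently at this nitrogen.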